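Trifluoromethyl in Place of Methyl on the Aryl Ring

A few compounds are considered here, and "the series" means these few. Any claim that something is new, unique, unknown or untested is made for them only; others in the source may bear on it.

Compound 2 `COc1cc2c(Oc3ccc(NC(=O)c4nn(-c5ccccc5C)c(=O)cc4C)cc3F)ccnc2cc1OCCCN1CCC(C)CC1` is one of three measured analogues that share a core and differ only in the saturated ring at the end of the chain. In a functional assay on A549 cells (Homo sapiens) for inhibition, read by MTT assay, with a stated time of 72 h (on this read-out lower numbers stand for stronger inhibition and higher numbers for weaker inhibition), compound 2 gives 1460 nM. Compound 1 `COc1cc2c(Oc3ccc(NC(=O)c4nn(-c5ccccc5C)c(=O)cc4C)cc3F)ccnc2cc1OCCCN1CCCCC1` gives 1920 nM, and compound 3 `COc1cc2c(Oc3ccc(NC(=O)c4nn(-c5ccccc5C)c(=O)cc4C)cc3F)ccnc2cc1OCCCN1CCN(C)CC1` gives 2830 nM. The measured steps are small: a 1.3-fold lower number from compound 1 to compound 2 (0.12 log units; within the scatter), a 1.5-fold higher number from compound 1 to compound 3 (0.17 log units; within the scatter) and a 1.9-fold higher number from compound 2 to compound 3 (0.29 log units; within the scatter). Compound 2 thus carries the lowest of the three numbers, yet each step to it lies within the scatter, so no order among the three can be read.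

Compound 4 `COc1cc2c(Oc3ccc(NC(=O)c4nn(-c5ccccc5C(F)(F)F)c(=O)cc4C)cc3F)ccnc2cc1OCCCN1CCC(C)CC1` differs from compound 2 in a different place: trifluoromethyl in place of methyl on an aromatic carbon. For the measured compounds named here, none of the three measured steps touches this aromatic ring; all of them concern the saturated ring on the chain, so no measured step bears on this change. With nothing in the data to set a direction, the step from compound 2 to compound 4 is expected to be a 1.0-fold higher number from compound 2 to compound 4 (0.01 log units; within the scatter), none beyond the scatter. Compound 4 is therefore estimated at 1500 nM, with a range from 500 nM to 4500 nM.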

Compound 4, half-maximal inhibitory concentration: 160 nM
Compound 4: middle estimate off by 9.4-fold (0.97 log units), on the high side, and the stated range ends above it.
By their numbers in this assay, from the lowest: compound 4; then compounds 2, 1 and 3 (each within the scatter of the next).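

In this assay the change from 2-methylphenyl to 2-(trifluoromethyl)phenyl gives a 9.1-fold lower number from compound 2 to compound 4 (0.96 log units; beyond the scatter) and is the only step among these compounds that lies beyond the scatter. The earlier compounds varied only the saturated ring on the chain, and none of their steps left the scatter, so this aromatic carbon, ortho to a large group, is the one place shown where a single change moves the number clearly. No measurement shown accounts for this step.

The compounds shown carry only methyl and trifluoromethyl at this carbon, so it stays open what hydrogen, chlorine, methoxy or a nitrile would give there. Going by these compounds, it also stays open whether the step holds with the piperidin-1-yl or 4-methylpiperazin-1-yl chain ends, as trifluoromethyl appears here only with 4-methylpiperidin-1-yl.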